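Lengthening the chain on the shared core

The compounds below may be only part of what the source reports. "The series", "measured", "known", "first", "only" and "open" are said of these compounds alone.

Compound 1 `CCCCCN1CCC(COC(c2ccccc2)c2ccccc2)CC1` gives 10800 nM
Compound 2 `CCCCCCN1CCC(COC(c2ccccc2)c2ccccc2)CC1` gives 5500 nM

Going by the values given here, in a functional assay on cells (T-cell line, Homo sapiens) for inhibition (on this read-out lower numbers stand for stronger inhibition and higher numbers for weaker inhibition), compound 2 stands within the scatter of compound 1, the only other measured compound. Compound 3 `CCCCCCCCCCN1CCC(COC(c2ccccc2)c2ccccc2)CC1` differs from compound 2 by butyl in place of hydrogen on a saturated chain carbon, six bonds along the chain from an amine nitrogen in a ring and nothing else. Among the compounds with values here, the one measured step bearing on this (a 2.0-fold lower number from compound 1 to compound 2 (0.29 log units; within the scatter)) added a single methyl and stays within the scatter, so it offers only a faint hint of direction. A moderate move toward a lower number is expected in this assay, though the added butyl reaches well beyond that evidence. The expected step is a 2.8-fold lower number from compound 2 to compound 3 (0.44 log units; beyond the scatter) and carries a wide margin. Compound 3 is estimated at 2000 nM (expected range 550 nM to 7000 nM).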

Compound 3, half-maximal inhibitory concentration: 2600 nM
Estimate against measurement, compound 3: 1.3-fold (0.11 log units) below; the range from low to high includes it.
By their numbers in this assay, from the lowest: compound 3; then compounds 2 and 1 (each within the scatter of the next).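

In this assay, going by these compounds alone, the added butyl gives the first step beyond the scatter (a 2.1-fold lower number from compound 2 to compound 3 (0.33 log units; beyond the scatter)). The pentyl change taken as a whole gives a larger step (a 4.2-fold lower number from compound 1 to compound 3 (0.62 log units; beyond the scatter)), so lengthening this chain does lower the number here, though both steps remain modest. No available evidence bears on what lies behind this change.

As far as these compounds go, it remains open whether a longer chain, such as dodecyl, would lower the number further or reverse the direction. Also open, from the compounds shown here alone, is whether a chain carrying a hydroxyl or a carboxylic acid would give a similar step.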